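Double-Bond Geometry Reversed at the Assay Limit

This account rests on a few compounds, and the source may have more. Where it says the series, first, only, none or still open, it means among the compounds named here.

The series shares one core and a benzyl-triazole ether on the pendant ring, and varies in what else the core carries. Compound 1 `O=C1Nc2ccc(F)cc2/C1=C\c1cccc(OCc2cn(Cc3ccccc3)nn2)c1` carries a fluorine; in a functional assay on DU-145 cells (Homo sapiens) for inhibition, read by MTT assay, with a stated time of 48 h (on this read-out higher numbers stand for weaker inhibition and lower numbers for stronger inhibition), compound 1 gives "not determined" (no result reported). Compound 2 `O=C1Nc2ccc(C(c3ccccc3)c3ccccc3)cc2/C1=C\c1cccc(OCc2cn(Cc3ccccc3)nn2)c1` carries a diphenylmethyl group instead. In this assay compound 2 gives > 50000 nM, which is a limit of the assay and not a number. Compound 3 `Cc1ccc(C(C#Cc2ccccc2)c2ccc3c(c2)/C(=C/c2cccc(OCc4cn(Cc5ccccc5)nn4)c2)C(=O)N3)cc1` carries a methine bearing a tolyl group and a phenylethynyl group. In this assay compound 3 gives > 50000 nM, again a limit and not a number, so compound 3 stands at the top of what is shown, alongside (the limit of > 50000 nM in this assay, at which 2 of the 3 values shown sit). For the measured compounds named here, no step between two measured compounds can be drawn from these figures, and nothing indicates how far past the limit either compound lies.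

Compound 4 `Cc1ccc(C(C#Cc2ccccc2)c2ccc3c(c2)/C(=C\c2cccc(OCc4cn(Cc5ccccc5)nn4)c2)C(=O)N3)cc1` differs from compound 3 only in the two compounds have the same atoms and bonds; at least one stereo element is drawn with a configuration in one of them and without one in the other: 1 of 2 stereo elements differ; a double bond is drawn Z in compound 3 and E in compound 4. Going by the values given here, with no measured step to lean on, the step from compound 3 to compound 4 in this assay is expected to be an at least 1.2-fold lower number from compound 3 to compound 4 (0.09 log units; that floor lies within the scatter), that is, none that clearly rises above the scatter, though the change of geometry leaves room for a difference in either direction. Compound 4 is therefore expected to give about 40000 nM, within 5000 nM to 200000 nM, and most likely again only a limit.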

Compound 4, half-maximal inhibitory concentration: 28900 nM
Beside the measured number, compound 4's estimate is 1.4-fold (0.14 log units) above it; the range from low to high includes it.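

For the compounds shown here, compound 4 is the first compound here to give a number and not a limit in this assay, which makes the double bond the first place where a change can be followed at all: the limit of > 50000 nM in this assay, at which 2 of the 4 values shown sit. As far as these compounds go, with nothing entering or leaving, the reversal of this double bond from Z to E gives an at least 1.7-fold lower number from compound 3 to compound 4 (0.23 log units; that floor lies within the scatter), so the smallest step the figures allow does not clear the usual scatter of this measurement, and the real size of the step stays unknown, as the starting point in compound 3 is a limit and not a number. The comparison also carries a caution about how the two structures are drawn, so the step cannot be read as a clean contrast between two fully defined forms: the fact that one of compounds 3 and 4 is drawn with a defined configuration and the other without, at the place where they differ.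

The compounds shown leave open whether the same reversal of geometry would change the result for the diphenylmethyl compound 2 or the fluorine compound 1, for which no result is reported. They also leave open what an amine or a carboxylic acid in place of the phenylethynyl group on the methine of compound 4 would give in this assay.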